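From Chlorine to Bromine on the Pendant Aromatic Ring

The source may hold more compounds than are shown below. What is called first, only, known or untested is meant among the compounds shown, and "the series" means these compounds.

Compound 1, `CC1=C(CC(=O)NCCN2CCCC2)c2cc(F)ccc2/C1=C\c1ccc([S+](C)[O-])cc1`: 52000 nM
Compound 2, `CC1=C(CC(=O)NCCN(C)C)c2cc(F)ccc2/C1=C\c1ccc([S+](C)[O-])cc1`: 47000 nM
Compound 3, `CC1=C(CC(=O)NCCN(C)C)c2cc(F)ccc2/C1=C\c1ccc(Cl)cc1`: 12400 nM

In a functional assay on HT-29 cells (Homo sapiens) for antiproliferative activity, read by MTT assay, with a stated time of 72 h (on this read-out lower numbers stand for stronger inhibition and higher numbers for weaker inhibition), compound 3 gives the lowest number of the three. The step of a 1.1-fold lower number from compound 1 to compound 2 (0.04 log units; within the scatter) separates the first two only within the scatter, while the step of a 3.8-fold lower number from compound 2 to compound 3 (0.58 log units; beyond the scatter) sets compound 3 apart from both. Compound 4, `CC1=C(CC(=O)NCCN(C)C)c2cc(F)ccc2/C1=C\c1ccc(Br)cc1`, differs from compound 3 by bromo in place of chloro on an aromatic carbon. Within the data shown here, no measured step exchanges one halogen for another; the nearest comparison, a 3.8-fold lower number from compound 2 to compound 3 (0.58 log units; beyond the scatter), concerns the same aromatic carbon but replaces a different group, so it gives only loose guidance. An exchange of chlorine for bromine at this position is expected to leave the number where it is, within the scatter: a 1.2-fold lower number from compound 3 to compound 4 (0.09 log units; within the scatter). Compound 4 is therefore estimated at 10000 nM, with a range from 4000 nM to 30000 nM.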

Compound 4, half-maximal inhibitory concentration: 20000 nM
For compound 4 the middle estimate is 2.0-fold (0.30 log units) below the measured one, within the range that was stated.
By their numbers in this assay, from the lowest: compounds 3 and 4 (each within the scatter of the next); then compounds 2 and 1 (each within the scatter of the next).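

Exchanging one halogen for the other on this aromatic carbon can now be read directly, and 4-chlorophenyl and 4-bromophenyl are not told apart in this assay (a 1.6-fold higher number from compound 3 to compound 4 (0.21 log units; within the scatter)). The gain from replacing the sulfur-bearing group is also not confined to chlorine, since bromine gives it too (a 2.4-fold lower number from compound 2 to compound 4 (0.37 log units; beyond the scatter)). Nothing available bears on the reason for either step.

Still open, on these data alone, is how a nitrile, a methoxy group or an amine on this same carbon would compare with the two halogens. A fluorine atom there is equally unsettled.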